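This account rests on a few compounds, and the source may have more. Where it says the series, first, only, none or still open, it means among the compounds named here.

Compound 2 `Cn1c(N2N=C(c3ccccc3)CC2c2ccc(F)cc2)nc(-c2ccccc2)c(C#N)c1=O` gives 11800 nM in a functional assay on MDA-MB-231 cells (Homo sapiens) for antiproliferative activity, with a stated time of 72 h; a higher number here means a weaker inhibitor, a lower number a stronger inhibitor. Among the three measured compounds it holds the second highest number: compound 1 `COc1ccc(C2CC(c3ccccc3)=NN2c2nc(-c3ccccc3)c(C#N)c(=O)n2C)cc1` gives 12800 nM, and compound 3 `Cc1ccc(C2=NN(c3nc(-c4ccccc4)c(C#N)c(=O)n3C)C(c3ccc(F)cc3)C2)cc1` gives 5100 nM. Compound 4 `Cn1c(N2N=C(c3ccccc3)CC2c2ccc(F)cc2)nc(-c2ccc(Cl)cc2)c(C#N)c1=O` differs from compound 2 by chloro in place of hydrogen on an aromatic carbon. Among the compounds with values here, no measured step makes this same change. The nearest comparison is a 2.3-fold lower number from compound 2 to compound 3 (0.36 log units; beyond the scatter), where a small group was added to an aromatic carbon of a different ring, while a 1.1-fold lower number from compound 1 to compound 2 (0.04 log units; within the scatter) swapped one group for another on a ring carbon. On this basis a modest move toward a lower number, or none beyond the scatter, is expected for compound 4, that is a 1.5-fold lower number from compound 2 to compound 4 (0.17 log units; within the scatter). Compound 4 is therefore estimated at 8000 nM, with a range from 4000 nM to 16000 nM.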

Compound 4, half-maximal inhibitory concentration: 20900 nM
Compound 4: the middle estimate sits 2.6-fold (0.42 log units) below what was measured; measured number outside the range, above it.
By their numbers in this assay, from the lowest: compound 3; then compounds 2, 1 and 4 (each within the scatter of the next).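

Replacing phenyl with 4-chlorophenyl gives a 1.8-fold higher number from compound 2 to compound 4 (0.25 log units; within the scatter) in this assay, so chloro at this place leaves the number within the scatter. Compounds 1, 2 and 3 all carry plain phenyl here, so they showed nothing about a change on this ring. No measurement shown explains this result. Going by these compounds, whether an amine or a carboxylic acid at this same place would move the number beyond the scatter remains open. So does whether chloro would act alike with the other groups of compound 3.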